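Adding a second fluorine to the aryl ring of compound 2

This account rests on a few compounds, and the source may have more. Where it says the series, first, only, none or still open, it means among the compounds named here.

Measured so far:
compound 1, `Cc1c(C=O)cc(-c2ccc(S(C)(=O)=O)cc2)n1-c1ccc(F)c(F)c1`, 60%
compound 2, `Cc1c(C#N)cc(-c2ccc(S(C)(=O)=O)cc2)n1-c1cccc(F)c1`, 38%

Of the compounds shown here, two on the shared core have been tested in a functional assay on the whole organism (strain Swiss albino) for inhibition, with Mus musculus as the target, in the writhing test, with a stated time of 30 min, at a dose of 40 mg/kg by the oral route; a higher number here means a stronger effect of the compound at the dose given, a lower number a weaker effect. Compound 1 gives 60% in this assay, and compound 2 gives 38%. Compound 2 thus stands lowest of the two numbers; its nearest neighbour is compound 1, a number higher by more than the usual scatter. Within the data shown here, the two compounds differ in more than one place, so no single step between them can be read off; their two values show only that compound 1 sits clearly higher.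

Compound 3, `Cc1c(C#N)cc(-c2ccc(S(C)(=O)=O)cc2)n1-c1ccc(F)c(F)c1`, has not yet been measured. It differs from compound 2 in one place:

fluoro in place of hydrogen on an aromatic carbon

Compound 3 carries a nitrile like compound 2 and a 3,4-difluorophenyl like compound 1. Among the measured compounds shown here, with no one-place step available, the expected step in this assay rests on those two values. Compound 3 is expected to land between them, an expected step of a number 10 percentage points higher from compound 2 to compound 3 (within the scatter), upward and at the edge of the scatter. Compound 3 is estimated at 48%, within a range from 30% to 65%.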

Compound 3, a percentage reported as inhibition, in the whole organism at one dose (the size of the read-out at that dose, not a potency): 57%
Estimate against measurement, compound 3: 9 percentage points below; the range from low to high includes it.
By their numbers in this assay, from the lowest: compound 2; then compounds 3 and 1 (each within the scatter of the next).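

In this assay, among these compounds, fluoro in place of hydrogen on an aromatic carbon, turning 3-fluorophenyl into 3,4-difluorophenyl with the nitrile kept, gives a number 19 percentage points higher from compound 2 to compound 3 (beyond the scatter), the first reading of this position through a change in one place. Cyano in place of formyl on an aromatic carbon, with the 3,4-difluorophenyl kept, gives a number 3 percentage points lower from compound 1 to compound 3 (within the scatter), so of the two places in which compound 1 and compound 2 differ, the step at the fluoro position is the one that lies beyond the scatter, while the two groups on the other place cannot be told apart with this aryl group. Nothing among the data shown accounts for the size of the fluoro step.

On these data alone, whether the fluoro step depends on the fluoro group itself remains open, since a chloro, methoxy or amino group at the same place would be needed to tell, and a single step on one nitrile pair cannot show whether it carries over to the formyl series. As far as these compounds go, each number also describes only the stronger or weaker effect of a compound at one oral dose, so whether the same holds at other doses stays unknown.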